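Urea series: heteroaryl swap on the benzyl arm

A few compounds are considered here, and "the series" means these few. Any claim that something is new, unique, unknown or untested is made for them only; others in the source may bear on it.

Two members of the series are measured in a functional assay on a cell-free system (plasma) with sterol O-acyltransferase, Soat (Rattus norvegicus) as the target (a higher number here means that more compound is needed for the effect, a lower number that less compound is needed), and both sit at the assay limit. Compound 1, `Cc1cc(C)c(NC(=O)N(Cc2cc(-c3ccccc3)on2)C2CCCCCC2)c(C)c1`, carries a phenyl-substituted isoxazole on the benzylic arm; in this assay compound 1 gives > 1 mg/kg, which is a limit and not a number. Compound 2, `Cc1cc(C)c(NC(=O)N(Cc2ccc(-c3cc[nH]n3)cc2)C2CCCCCC2)c(C)c1`, carries a pyrazole on the benzyl ring; in this assay compound 2 gives > 1 mg/kg, again a limit rather than a number. Among the measured compounds shown here, no step between measured compounds can be computed, so all that can be said is the limit of > 1 mg/kg in this assay, at which 2 of the 2 values shown sit: both values are limits at the same point, and neither compound stands apart from the other.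

Compound 3, `Cc1cc(C)c(NC(=O)N(Cc2ccc(-n3nccn3)cc2)C2CCCCCC2)c(C)c1`, differs from compound 2 by 2H-1,2,3-triazol-2-yl in place of 1H-pyrazol-3-yl on an aromatic carbon. For the measured compounds named here, with no measured step to lean on and both measured values at the limit, no direction beyond the scatter is expected for the change from compound 2 to compound 3. Compound 3 is therefore estimated at 1.5 mg/kg, between 0.5 mg/kg and 5 mg/kg, with a reporting as a limit again the most likely outcome; the step from compound 2 to compound 3 is expected to be a step that the limit leaves unreadable from compound 2 to compound 3.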

Compound 3, dose for half-maximal effect: > 1 mg/kg
Compound 3: no number, only a limit (the forecaster's own chance of this, stated with the estimate: 75%); the middle value does not contradict the limit.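

In this assay compound 3 gives > 1 mg/kg, which is a limit and not a number. No step can be read from compound 2 to compound 3: the limit of > 1 mg/kg in this assay, at which 3 of the 3 values shown sit.

The compounds shown leave open how far each value lies from that limit, and whether 2H-1,2,3-triazol-2-yl and 1H-pyrazol-3-yl differ at all in this assay.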